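Adding a hydroxy group to compound 3

The source may hold more compounds than are shown below. What is called first, only, known or untested is meant among the compounds shown, and "the series" means these compounds.

Among the measured compounds shown here, compound 3 `COc1ccc(C(=O)/C=C/c2ccccc2-c2ccc(F)nc2)cc1` gives 10000 nM in a functional assay on SW480 cells (Homo sapiens) for antiproliferative activity, read by sulforhodamine B assay, with a stated time of 48 h (a higher number here means a weaker inhibitor, a lower number a stronger inhibitor), and sits, together with compound 2 `COc1ccc(C(=O)/C=C/c2ccccc2-c2ccc(F)cc2)cc1` at 8400 nM on the measured scale, at the high, weak end of the three numbers so far. Compound 1 `COc1ccc(/C=C/C(=O)c2ccccc2-c2ccc(OC)c(OC)c2OC)cc1O` gives 170 nM and lies far lower. Compound 4 `COc1ccc(C(=O)/C=C/c2ccccc2-c2ccc(F)nc2)cc1O` comes from compound 3 through hydroxy in place of hydrogen on an aromatic carbon with the new group ortho to a methoxy group. For the measured compounds named here, the only measured step of a 1.2-fold higher number from compound 2 to compound 3 (0.08 log units; within the scatter) swaps a different group and says little here. Compound 1 also holds a hydroxy ortho to a methoxy group, and its 170 nM hints at a lower number, though its structure differs elsewhere too. A moderate fall is expected, estimated as a 3.3-fold lower number from compound 3 to compound 4 (0.52 log units; beyond the scatter) in this assay with wide uncertainty. Compound 4 is estimated at 3000 nM with an expected range from 600 nM to 12000 nM in this assay overall.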

Compound 4, half-maximal inhibitory concentration: 1600 nM
Compound 4: the middle estimate sits 1.9-fold (0.27 log units) above what was measured, within the range that was stated.
By their numbers in this assay, from the lowest: compound 1; then compound 4; then compounds 2 and 3 (each within the scatter of the next).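

In this assay, among the compounds shown here, hydroxy in place of hydrogen, ortho to a methoxy group, gives a 6.3-fold lower number from compound 3 to compound 4 (0.80 log units; beyond the scatter) and is the first single change here that lies beyond the scatter. A single added oxygen at this position therefore moves the number, which the earlier exchange of 4-fluorophenyl for 6-fluoropyridin-3-yl did not do. No measurement given here bears on the reason for this fall. The compounds shown leave open whether an amine or a carboxylic acid at this position would lower the number as far. They also leave open whether hydroxy would give a similar step on compound 2.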